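The source may hold more compounds than are shown below. What is called first, only, known or untested is meant among the compounds shown, and "the series" means these compounds.

Compound 1 `Cc1ccc(-c2cs/c(=N/NC(=O)CSc3nnnn3-c3ccccc3)n2-c2ccccc2)cc1` holds the lowest of three numbers in a functional assay on C6 cells (Rattus norvegicus) for cytotoxicity, read by MTT assay, with a stated time of 24 h, tested at 50 ug/mL (on this read-out lower numbers stand for a stronger effect and higher numbers for a weaker effect at the one concentration tested), where compound 1 gives 29.5%. Nearest stands compound 3 `O=C(CSc1nnnn1-c1ccccc1)N/N=c1/scc(-c2ccccc2)n1-c1ccccc1`, which gives 36.7%; furthest stands compound 2 `O=C(CSc1nnnn1-c1ccccc1)N/N=c1/scc(-c2ccc(F)cc2)n1-c1ccccc1`, which gives 43.7%. The step of a number 7.2 percentage points higher from compound 1 to compound 3 (within the scatter) lies within the scatter, while a number 14.2 percentage points higher from compound 1 to compound 2 (beyond the scatter) lies beyond it, and a number 7 percentage points lower from compound 2 to compound 3 (within the scatter) is again within it. Compound 4 `Cc1ccc(-c2cs/c(=N/NC(=O)CSc3nnc(C)s3)n2-c2ccccc2)cc1` differs from compound 1 in one place: 5-methyl-1,3,4-thiadiazol-2-yl in place of 1-phenyl-1H-tetrazol-5-yl on a sulfur. Among the compounds with values here, none of the measured steps touches this part of the molecule, since each of them changed only the group on the aromatic carbon, so no measured guide for this step exists, and no change beyond the scatter is expected. Compound 4 is therefore expected to give 35% in this assay, between 15% and 60%, a step of a number 5.5 percentage points higher from compound 1 to compound 4 (within the scatter).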

Compound 4, a percentage reported as activity, at one concentration (the size of the read-out at that concentration, not a potency): 40.6%
Estimate against measurement, compound 4: 5.6 percentage points below, within the range that was stated.
By their numbers in this assay, from the lowest: compounds 1, 3, 4 and 2 (each within the scatter of the next, the first and the last beyond it).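

Within the data shown here, the group on the sulfur does bear on the read-out in this assay: 5-methyl-1,3,4-thiadiazol-2-yl in place of 1-phenyl-1H-tetrazol-5-yl gives a number 11.1 percentage points higher from compound 1 to compound 4 (beyond the scatter), a modest step at a position the earlier steps left untouched. This single change also replaces two aromatic rings with one, so the pair cannot separate those two differences. Nothing available explains the step.

On these data alone, it remains open whether the step would persist with fluoro or hydrogen on the aromatic carbon. As far as these compounds go, it is also open how a carboxylic acid or a butyl chain on this sulfur would compare.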